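The source may report more compounds than this note shows. Statements on the series, on what has been measured and on what is new or still open speak of the compounds shown alone.

Working notes on the series.

The series shares one core with a thiophene-bearing and a fluorophenyl-bearing substituent, and varies the group on the distal phenyl ring. Compound 1 `Cc1ccc(C2=NN(c3nc(-c4ccc(C#N)cc4)cs3)C(c3ccc(F)cc3)C2)s1` gives 250 ug/mL in an ADME assay on NIH3T3 cells (Mus musculus) for cytotoxicity, read by XTT assay, with a stated time of 24 h; a lower number here means a stronger inhibitor, a higher number a weaker inhibitor. Within the data shown here, compound 3 `Cc1ccc(C2=NN(c3nc(-c4ccc(S(C)(=O)=O)cc4)cs3)C(c3ccc(F)cc3)C2)s1` gives 374 ug/mL in this assay; the step of a 1.5-fold higher number from compound 1 to compound 3 (0.17 log units; within the scatter) is the only fully measured step so far. Compound 2 `Fc1ccc(C2CC(c3ccc(Cl)s3)=NN2c2nc(-c3ccc(C(F)(F)F)cc3)cs2)cc1` reaches only the limit of the assay in this assay, > 500 ug/mL, so no number is known for it, and this is the reading described at the limit of > 500 ug/mL in this assay, at which 1 of the 3 values shown sits.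

Compound 4 `Cc1ccc(-c2csc(N3N=C(c4ccc(Cl)s4)CC3c3ccc(F)cc3)n2)cc1` is not yet measured. It differs from compound 2 by methyl in place of trifluoromethyl on an aromatic carbon. Among the measured compounds shown here, the one measured step, which also exchanges a group on an aromatic carbon of the same ring, is a 1.5-fold higher number from compound 1 to compound 3 (0.17 log units; within the scatter), within the scatter, and no measured step here reaches beyond the scatter. Compound 2 itself provides only a limit, so the starting point is open at its upper end. The step of an at least 1.2-fold lower number from compound 2 to compound 4 (0.09 log units; that floor lies within the scatter) is therefore expected to be small, with no clear direction, and compound 4 may again run into the limit. The estimate for compound 4 in this assay is 400 ug/mL, with a range from 200 ug/mL to 800 ug/mL.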

Compound 4, half-maximal inhibitory concentration: > 500 ug/mL
Compound 4: a limit, no number (the forecaster's own chance of this, stated with the estimate: 45%); middle value at least 1.2-fold (0.09 log units) away from the limit.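

Compound 4 reaches only a limit in this assay, > 500 ug/mL, and not a number. Among these compounds, compound 2 also stands at a limit, so no step between compound 2 and compound 4 can be read: the limit of > 500 ug/mL in this assay, at which 2 of the 4 values shown sit. The compounds shown leave open whether 4-(trifluoromethyl)phenyl and 4-methylphenyl differ at all in this assay.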